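From hept-1-yn-1-yl to hydroxy on the shared core

A few compounds are considered here, and "the series" means these few. Any claim that something is new, unique, unknown or untested is made for them only; others in the source may bear on it.

In an ADME assay on L1210/0 cells (Mus musculus) for cytotoxicity, with a stated time of 48 h (on this read-out lower numbers stand for stronger inhibition and higher numbers for weaker inhibition), compound 1 (`O=c1[nH]c(=O)n([C@H]2C[C@H](O)[C@@H](CO)O2)cc1C#CCCO`) gives > 200000 nM as a limit and not a number. Compound 2 (`CCCCCC#Cc1cn([C@H]2C[C@H](O)[C@@H](CO)O2)c(=O)[nH]c1=O`) gives > 200000 nM as a limit too. For the measured compounds named here, compound 2 therefore has no readable position, and the one further value shown for the series is also a limit.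

Compound 3 (`O=c1[nH]c(=O)n([C@H]2C[C@H](O)[C@@H](CO)O2)cc1O`) has hydroxy in place of hept-1-yn-1-yl on an aromatic carbon, a change counted as hydroxy in place of hept-1-yn-1-yl on an aromatic carbon with the rest of the core unchanged.

The step that the two limits leave unreadable from compound 1 to compound 2 is the only measured one and gives no size to carry over. The evidence so far is the limit of > 200000 nM in this assay, at which 2 of the 2 values shown sit, and no graded value exists yet. The expected size of a number no higher from compound 2 to compound 3 (the limit leaves the size open) in this assay is therefore none beyond the scatter, with no direction expected. Compound 3 is estimated at 200000 nM with an expected range of 60000 nM to 400000 nM, and a limit rather than a number may well be expected.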

Compound 3, half-maximal inhibitory concentration: > 200000 nM
Compound 3: no number, only a limit (the forecaster's own chance of this, stated with the estimate: 75%); the middle value lies on the limit itself.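

In this assay, for the compounds shown here, compound 1, compound 2 and compound 3 all give limits and not numbers, so no step among them can be read. The compounds shown leave open whether hept-1-yn-1-yl, 4-hydroxybut-1-yn-1-yl or hydroxy on this aromatic carbon of the shared core makes any difference to the read-out, and how large that difference would be.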